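The compounds below may be only part of what the source reports. "The series", "measured", "known", "first", "only" and "open" are said of these compounds alone.

Measured compounds:
compound 1, `Cc1c(OCCCCOc2ccccc2C(=O)O)ccc(C(=O)CC2CCCC2)c1O`, 335 nM
compound 2, `Cc1c(OCCCCOc2ccc(C(=O)O)c(Cl)c2)ccc(C(=O)CC2CCCC2)c1O`, 510 nM
compound 3, `Cc1c(OCCCCOc2ccc(C(=O)O)c(Cl)c2)ccc(C(=O)CC(C)C)c1O`, 151 nM

The three were measured in an assay on HEK293 cells for positive allosteric modulation of metabotropic glutamate receptor 2 (Rattus norvegicus), read by thallium flux, with a stated time of 2.5 min; a lower number here means that less compound is needed, a higher number that more compound is needed for the effect. Compound 2 and compound 1 differ by 2-carboxyphenyl in place of 4-carboxy-3-chlorophenyl on an oxygen on a saturated carbon, and that step reads a 1.5-fold lower number from compound 2 to compound 1 (0.18 log units; within the scatter). Compound 2 and compound 3 differ by isopropyl in place of cyclopentyl on a saturated chain carbon bound to a carbonyl carbon, with a 3.4-fold lower number from compound 2 to compound 3 (0.53 log units; beyond the scatter); compound 3 holds the lowest of the three numbers.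

Compound 4, `Cc1c(OCCCCOc2ccccc2C(=O)O)ccc(C(=O)CC(C)C)c1O`, has not been measured. It differs from compound 3 by 2-carboxyphenyl in place of 4-carboxy-3-chlorophenyl on an oxygen on a saturated carbon, the same change already seen from compound 2 to compound 1. The two cores differ in the way the counted difference between compound 2 and compound 3 describes. Since the earlier step stayed within the scatter, the step from compound 3 to compound 4 is expected to be small, a 1.4-fold lower number from compound 3 to compound 4 (0.16 log units; within the scatter), resting on compound 3 with 151 nM. Compound 4 is estimated at 105 nM, between 40 nM and 270 nM.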

Compound 4, half-maximal effective concentration: 415 nM
The estimate for compound 4 lay 4.0-fold (0.60 log units) below the measured number; the measured number lies above the stated range.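

In this assay, 2-carboxyphenyl in place of 4-carboxy-3-chlorophenyl gave a 2.7-fold higher number from compound 3 to compound 4 (0.44 log units; beyond the scatter), which does not match the earlier step on the cyclopentyl core: the same change on two cores in this assay, a 1.5-fold lower number (0.18 log units; within the scatter) from compound 2 to compound 1 and a 2.7-fold higher number (0.44 log units; beyond the scatter) from compound 3 to compound 4, 4.2-fold (0.62 log units) apart, beyond the scatter of two such steps. Isopropyl in place of cyclopentyl gave a 1.2-fold higher number from compound 1 to compound 4 (0.09 log units; within the scatter) on the 2-carboxyphenyl core, which also departs from its earlier step: the same change on two cores in this assay, a 3.4-fold lower number (0.53 log units; beyond the scatter) from compound 2 to compound 3 and a 1.2-fold higher number (0.09 log units; within the scatter) from compound 1 to compound 4, 4.2-fold (0.62 log units) apart, beyond the scatter of two such steps. Neither change carried over unaltered between these cores, but a single set of four compounds does not show how either change would behave on any other core, or why the steps differ.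

The exchange alters the chlorine and the place of the carboxylic acid together, so 4-carboxyphenyl without the chlorine would be needed to separate them. From the compounds shown here alone, whether a tetrazole in place of the carboxylic acid would show the same dependence on the core remains open.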